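Swapping a fluorine for an amine side chain

A few compounds are considered here, and "the series" means these few. Any claim that something is new, unique, unknown or untested is made for them only; others in the source may bear on it.

Compound 1 `COc1cc(F)c(NC(=O)c2cnccn2)cc1Nc1nccc(-c2cn(C)c3ccccc23)n1` was tested in a functional assay on A549 cells (Homo sapiens) for antiproliferative activity, read by MTT assay, with a stated time of 72 h (a higher number here means a weaker inhibitor, a lower number a stronger inhibitor), where it gives 2490 nM. For the measured compounds named here, that is the lowest of the two numbers measured so far; its nearest neighbour, compound 2 `COc1cc(F)c(NC(=O)c2nccn2C)cc1Nc1nccc(-c2cn(C)c3ccccc23)n1`, gives 5140 nM in this assay. Going by the values given here, the one step measured between them, a 2.1-fold higher number from compound 1 to compound 2 (0.31 log units; beyond the scatter), concerns the group on the carbonyl carbon and is modest in size.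

Compound 3 `COc1cc(N(C)CCN(C)C)c(NC(=O)c2cnccn2)cc1Nc1nccc(-c2cn(C)c3ccccc23)n1` differs from compound 1 elsewhere: (2-(dimethylamino)ethyl)(methyl)amino in place of fluoro on an aromatic carbon. Among the compounds with values here, no measured step touches this position, so the step from compound 1 to compound 2 gives no direct guide; it only shows that a change on the same core moved the number modestly.

Compound 3 is therefore expected to give about 1500 nM in this assay, within a range of 400 nM to 6000 nM. That expectation amounts to a step of a 1.7-fold lower number from compound 1 to compound 3 (0.22 log units; within the scatter), with wide uncertainty.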

Compound 3, half-maximal inhibitory concentration: 4330 nM
For compound 3 the middle estimate is 2.9-fold (0.46 log units) below the measured one; the range from low to high includes it.
By their numbers in this assay, from the lowest: compounds 1, 3 and 2 (each within the scatter of the next, the first and the last beyond it).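

In this assay, putting (2-(dimethylamino)ethyl)(methyl)amino in place of fluoro gives a 1.7-fold higher number from compound 1 to compound 3 (0.24 log units; within the scatter). For the compounds shown here, this is the first look at this position, on the aromatic carbon ortho to the ((pyrazin-2-yl)carbonyl)amino group, and it shows that a chain of 7 heavy atoms can replace a single fluorine with no change in the number beyond the usual scatter. Nothing measured here bears on the reason for this result.

The compounds shown leave open whether a shorter amine chain, a piperazine ring or a simple hydroxyl group at this position would also read the same. They also leave open whether the chain behaves alike with 1-methyl-1H-imidazol-2-yl on the carbonyl carbon, since here it appears only with pyrazin-2-yl.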